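Trimming a methyl from the aryl sulfone of compound 1

The source may report more compounds than this note shows. Statements on the series, on what has been measured and on what is new or still open speak of the compounds shown alone.

Measured so far:
- compound 1 `COc1ccc2ncc(S(=O)(=O)c3ccc(C)c(Cl)c3)c(N3CCC(C)CC3)c2c1`: 85%
- compound 2 `CC1CCN(c2c(S(=O)(=O)c3cc(Cl)cc(Cl)c3)cnc3ccc(F)cc23)CC1`: 69%

In an assay on isolated protein for displacement of a labelled ligand from metabotropic glutamate receptor 5 (Homo sapiens), with a stated time of 60 min, tested at 1 uM (a lower number here means less inhibition, a higher number more inhibition at the concentration tested (going by the name of the read-out)), compound 1 gives 85%, the higher of the two numbers; compound 2 gives 69%, a number lower by more than the scatter. Compound 2 differs from compound 1 in more than one place, so its two values show only the gap, not its source. Compound 3 `COc1ccc2ncc(S(=O)(=O)c3ccc(Cl)cc3)c(N3CCC(C)CC3)c2c1` is a single change from compound 1: 4-chlorophenyl in place of 3-chloro-4-methylphenyl on a sulfonyl sulfur. Among the measured compounds shown here, no measured pair shows this change, so the step from compound 1 to compound 3 is expected to be small, a slight fall that may stay within the scatter: a number 10 percentage points lower from compound 1 to compound 3 (within the scatter). For compound 3 the expected value is 75%, with a range from 55% to 90%.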

Compound 3, a percentage reported as inhibition, at one concentration (the size of the read-out at that concentration, not a potency): 91%
Beside the measured number, compound 3's estimate is 16 percentage points below it; measured number above the stated range.
By their numbers in this assay, from the lowest: compound 2; then compounds 1 and 3 (each within the scatter of the next).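

Among the compounds shown here, compound 3 gives the first single-change comparison here: in this assay, 4-chlorophenyl in place of 3-chloro-4-methylphenyl on a sulfonyl sulfur gives a number 6 percentage points higher from compound 1 to compound 3 (within the scatter). The methyl group can therefore go from this aryl ring without a reading outside the scatter, at this one tested concentration. Nothing available gives a reason for this result.

Still open, as far as these compounds go, is how this position responds to a clearly different group in place of the chlorine, such as an amine or a carboxylic acid. A single-concentration reading also leaves the potencies of compound 1 and compound 3 unknown.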